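The source may hold more compounds than are shown below. What is called first, only, known or untested is meant among the compounds shown, and "the series" means these compounds.

Series notes. Of the compounds shown here, three of the shared core have been measured in a functional assay on TK-10 cells (Homo sapiens) for inhibition, read by sulforhodamine B assay, with a stated time of 48 h; a higher number here means a weaker inhibitor of growth, a lower number a stronger inhibitor of growth. Compound 1 `COc1cc(C)cc(-c2nn(CC#N)cc2-c2ccc(-c3cccc(C(C)=O)c3)nc2)c1` gives 11500 nM; compound 2 `Cc1cc(O)cc(-c2nn(CC#N)cc2-c2ccnc(-c3ccc(Oc4ccccc4)cc3)c2)c1` gives 15100 nM; compound 3 `COc1cc(C)cc(-c2nn(CC#N)cc2-c2ccnc(-c3ccc(N(C)C)cc3)c2)c1` gives 78900 nM. Compound 3 stands at the highest number of the three; the nearest, compound 2, and the furthest, compound 1, both lie beyond the scatter from it, so compound 3 is the weakest inhibitor of growth among the measured compounds. Compound 4 `Cc1cc(O)cc(-c2nn(CC#N)cc2-c2ccnc(-c3ccc(N(C)C)cc3)c2)c1` has not yet been measured. It differs from compound 3 in one place: hydrogen in place of methyl on an oxygen on an aromatic ring. Going by the values given here, compound 2 carries the same hydroxy-bearing ring as compound 4 but also differs from compound 3 elsewhere, so no measured pair isolates this change on its own. In this assay the expected step is small, a 1.4-fold lower number from compound 3 to compound 4 (0.16 log units; within the scatter), with no direction that clearly exceeds the scatter; a shift toward lower numbers is the more likely side, given that compound 2 gives 15100 nM with the hydroxy in place. Compound 4 is expected at 55000 nM, within 20000 nM to 150000 nM.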

Compound 4, concentration for total growth inhibition: 57800 nM
The estimate for compound 4 lay 1.1-fold (0.02 log units) below the measured number, within the range that was stated.
By their numbers in this assay, from the lowest: compounds 1 and 2 (each within the scatter of the next); then compounds 4 and 3 (each within the scatter of the next).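

In this assay, the change from methoxy to hydroxy on the 3-methoxy-5-methylphenyl group can now be read on its own, with the dimethylamino group held constant: a 1.4-fold lower number from compound 3 to compound 4 (0.14 log units; within the scatter), so hydrogen in place of methyl on this oxygen leaves the number within the scatter. With the hydroxy group held constant, dimethylamino in place of phenoxy on an aromatic carbon gives a 3.8-fold higher number from compound 2 to compound 4 (0.58 log units; beyond the scatter), and of the two steps only this one lies beyond the scatter. Nothing available bears on the reason for either step.

From the compounds shown here alone, it remains open whether the methoxy to hydroxy change stays as small with phenoxy on that aromatic carbon. Also open, going by these compounds, is what an amine or a longer chain such as ethoxy would do in place of the hydroxy group.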